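A few compounds are considered here, and "the series" means these few. Any claim that something is new, unique, unknown or untested is made for them only; others in the source may bear on it.

Measured so far:
Compound 1 `CC1=CC[C@H](C(C)(C)NC(=S)N/N=C/c2ccc(F)cc2)CC1`; in a functional assay on U-251 cells (Homo sapiens) for inhibition, read by sulforhodamine B assay, with a stated time of 48 h (a higher number here means a weaker inhibitor of growth, a lower number a stronger inhibitor of growth), compound 1 gives > 100000 nM, which is a limit of the assay and not a number.
Compound 2 `CC1=CC[C@H](C(C)(C)NC(=S)N/N=C/c2ccc(Cl)cc2)CC1`; in this assay compound 2 gives 69500 nM.

Among the measured compounds shown here, compound 2 therefore holds the only number in this assay, the other value being a limit. For the measured compounds named here, the single measured step, an at least 1.4-fold lower number from compound 1 to compound 2 (0.15 log units; that floor lies within the scatter), is the change of chloro in place of fluoro on the aromatic carbon, and its size rests on (the limit of > 100000 nM in this assay, at which 1 of the 2 values shown sits), so it gives no firm direction.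

Compound 3 `CC1=CC[C@H](C(C)(C)NC(=S)N/N=C/c2ccc[nH]2)CC1` differs from compound 2 by 1H-pyrrol-2-yl in place of 4-chlorophenyl on a carbon with a double bond to nitrogen. Going by the values given here, no measured step exchanges the whole aromatic ring, and the one step available alters only a halogen on that ring, so the expectation for compound 3 is drawn with wide margins and a real chance that this assay again returns only a limit. Compound 3 is expected to give about 90000 nM in this assay, within 35000 nM to 200000 nM. The expected step of a 1.3-fold higher number from compound 2 to compound 3 (0.11 log units; within the scatter) is thus estimated to stay within the ordinary scatter of such measurements.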

Compound 3, concentration for 50% growth inhibition: 80 nM
Estimate against measurement, compound 3: 1100-fold (3.05 log units) above; the measured number lies below the stated range.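

On the carbon with a double bond to nitrogen, the identity of the ring turns out to matter far more in this assay than the earlier halogen change could suggest: 1H-pyrrol-2-yl in place of 4-chlorophenyl gives an 870-fold lower number from compound 2 to compound 3 (2.94 log units; beyond the scatter). The same kind of exchange, with 4-fluorophenyl leaving, gives an at least 1200-fold lower number from compound 1 to compound 3 (3.09 log units; beyond the scatter), and that figure is a floor and not a full size: the limit of > 100000 nM in this assay, at which 1 of the 3 values shown sits. Across these three compounds, then, swapping the whole ring produces a large step beyond the scatter, whereas the halogen change on the phenyl ring alone gave no firm direction.

The compounds shown cannot separate what the exchange combines, namely the smaller five-membered ring, its ring nitrogen and the hydrogen-bond donor counted on it, so a furan-2-yl or thiophen-2-yl ring, or a pyrrol-2-yl ring with a methyl group on its nitrogen, would be needed to tell these apart. They also leave open whether a pyrrol-3-yl ring at this place would behave like 1H-pyrrol-2-yl, and whether the step holds on other cells.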